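Swapping cycloheptyl for cyclohexyl in a solubility series

The source may report more compounds than this note shows. Statements on the series, on what has been measured and on what is new or still open speak of the compounds shown alone.

In a physicochemical assay for solubility, at pH 7.4 (a lower number here means a less soluble compound, a higher number a more soluble compound), compound 1 `CCCCCCCc1cc(-c2ccc(CNC(=O)[C@H]3NCC[C@@H]3O)cc2)n[nH]1` gives 3.7 ug/mL. Compound 2 `CCCCCCc1nc(-c2ccc(CNC(=O)[C@H]3NCC[C@@H]3O)cc2)no1` reads > 50 ug/mL, which is a limit of the assay and not a number. Compound 3 `O=C(NCc1ccc(-c2noc(C3CCCCCC3)n2)cc1)[C@H]1NCC[C@@H]1O` reads > 50 ug/mL, which is also a limit and not a number. Only a limit is therefore known for compound 3, and that reading is the limit of > 50 ug/mL in this assay, at which 2 of the 3 values shown sit.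

Compound 4 `O=C(NCc1ccc(-c2noc(C3CCCCC3)n2)cc1)[C@H]1NCC[C@@H]1O` carries one structural change from compound 3: cyclohexyl in place of cycloheptyl on an aromatic carbon. Among the measured compounds shown here, the one measured step that bears on this swap is also a change of group on an aromatic carbon, namely a step that the two limits leave unreadable from compound 2 to compound 3. That step offers no size to carry over, so no shift beyond the usual scatter is expected in this assay, and no direction can be assigned. The estimated change is a step that the limit leaves unreadable from compound 3 to compound 4. Compound 4 is expected to give about 60 ug/mL, with an estimated range of 25 ug/mL to 150 ug/mL.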

Compound 4, solubility: > 50 ug/mL
Compound 4 ended at the assay's limit; the forecaster's own chance of this, stated with the estimate: 80%; the middle value is on the limit's open side.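

In this assay compound 4 reads > 50 ug/mL, which is a limit of the assay and not a number. Among the compounds shown here, compound 2, compound 3 and compound 4 all sit at this limit, and no step among them can be read. As far as these compounds go, how far apart these three truly lie in this assay remains open.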